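Fluoro in Place of Carboxy: From Compound 2 to Compound 4

This account rests on a few compounds, and the source may have more. Where it says the series, first, only, none or still open, it means among the compounds named here.

Measured compounds:
Compound 1 `CCn1c(-c2ccccc2)nc2c(NC3CCC3)ncnc21` gives 6 nM.
Compound 2 `Cn1c(-c2ccc(C(=O)O)cc2)nc2c(NC3CCCC3)ncnc21` gives 54000 nM.
Compound 3 `CCCn1c(-c2ccccc2)nc2c(N)ncnc21` gives 101 nM.

For the measured compounds named here, of the three numbers known in an assay on CHO cells for displacement of a labelled ligand from adenosine receptor A1 (Homo sapiens), read by scintillation counting, with a stated time of 3 h (a lower number here means a stronger inhibitor, a higher number a weaker inhibitor), compound 2 stands highest, and the gap to both others lies beyond the usual scatter. Its nearest neighbour is compound 3, already far lower, and compound 1 lies lower still, the lowest of the three. Compound 2 is also the only one of the three that carries a carboxy on its phenyl; compound 1 and compound 3 carry an unsubstituted phenyl.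

Compound 4 `Cn1c(-c2ccc(F)cc2)nc2c(NC3CCCC3)ncnc21` keeps the core, the methyl on the nitrogen and the cyclopentylamino of compound 2 and alters only the phenyl substituent:

fluoro in place of carboxy on an aromatic carbon

Going by the values given here, no directly comparable pair of measured compounds is available for this change, so the expectation rests on the standing of compound 2 against compound 1 and compound 3. Since the two carboxy-free compounds sit so far below compound 2, a large step downward in this assay, well beyond the scatter, is expected from a 900-fold lower number from compound 2 to compound 4 (2.95 log units; beyond the scatter). Compound 4 is therefore estimated at 60 nM, within a range from 6 nM to 600 nM.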

Compound 4, inhibition constant: 6.2 nM
Beside the measured number, compound 4's estimate is 9.7-fold (0.99 log units) above it; the measured number falls inside the stated range.
By their numbers in this assay, from the lowest: compounds 1 and 4 (each within the scatter of the next); then compound 3; then compound 2.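

In this assay, for the compounds shown here, the earlier compounds differ from compound 2 in more than one place, so they could not set the carboxy apart from the other differences among them. The exchange of carboxy for fluoro, on an aromatic carbon para to a large group, isolates this one position, with the core, the methyl on the nitrogen and the cyclopentylamino left as they stand, and it gives an 8700-fold lower number from compound 2 to compound 4 (3.94 log units; beyond the scatter), so a change at this position alone is enough for a step of this size. Nothing available here explains why the number moves so far with this change.

Still open, from the compounds shown here alone, is whether a plain hydrogen at this position would give a number close to that of compound 4 or to that of compound 2, which would separate the loss of the carboxy from the arrival of the fluoro. Also open, going by these compounds, is how a carboxamide, an amine, a methoxy or a chloro would stand at the same place, and whether a carboxylic acid at the end of a longer chain would stand as high as compound 2.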